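The source may report more compounds than this note shows. Statements on the series, on what has been measured and on what is new or still open speak of the compounds shown alone.

Compound 1 `CCN(Cc1ccc2nc(C)[nH]c(=O)c2c1)c1ccc(C(=O)N[C@@H](CCC(=O)O)C(=O)O)c(F)c1` is a quinazolinone antifolate analogue bearing a fluorine on the benzoyl ring and an ethyl group on the bridging nitrogen. In an assay on isolated protein for inhibition of Thymidylate synthase (Mus musculus) (on this read-out lower numbers stand for stronger inhibition and higher numbers for weaker inhibition), compound 1 gives 45 nM, the lowest of the two numbers recorded. Its nearest neighbour is compound 2 `CCN(Cc1ccc2nc(C)[nH]c(=O)c2c1)c1ccc(C(=O)N[C@@H](CCC(=O)O)C(=O)O)c(Cl)c1`, which in this assay gives 120 nM; the step of a 2.7-fold higher number from compound 1 to compound 2 (0.43 log units; beyond the scatter) shows how much the halogen exchange costs. Compound 3 `C#CCN(Cc1ccc2nc(C)[nH]c(=O)c2c1)c1ccc(C(=O)N[C@@H](CCC(=O)O)C(=O)O)c(F)c1` keeps the fluoro substituent of compound 1 but alters the nitrogen substituent: ethynyl in place of methyl on a saturated chain carbon bound to a nitrogen on an aromatic ring. Among the compounds with values here, no measured step touches this part of the shared core, since the only recorded step concerns the aromatic halogen. With nothing to guide the direction, compound 3 is expected to land close to compound 1, with a step of a 1.1-fold lower number from compound 1 to compound 3 (0.05 log units; within the scatter) that is not expected to exceed the scatter. The estimate for compound 3 is therefore 40 nM, within a range from 14 nM to 115 nM.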

Compound 3, half-maximal inhibitory concentration: 20 nM
Estimate against measurement, compound 3: 2.0-fold (0.30 log units) above, within the range that was stated.
By their numbers in this assay, from the lowest: compound 3; then compound 1; then compound 2.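

In this assay, the change from ethyl to propargyl gives a 2.3-fold lower number from compound 1 to compound 3 (0.35 log units; beyond the scatter), the first step read at this place on a saturated chain carbon bound to a nitrogen on an aromatic ring. The earlier halogen step said nothing about this place; this step shows that the number responds to a change here and that the ethynyl group is tolerated, with a lower number rather than a higher one. Nothing available gives a measured reason for this step.

An allyl or propyl group at the same place would help show whether the lower number goes with the triple bond or with the longer chain. As far as these compounds go, it also remains open whether propargyl in place of ethyl would give a step of similar size alongside the chloro group of compound 2.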